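Naphthalen-1-yl on the sulfur side chain

A few compounds are considered here, and "the series" means these few. Any claim that something is new, unique, unknown or untested is made for them only; others in the source may bear on it.

Within the data shown here, in an ADME assay on GES1 cells (Homo sapiens) for inhibition, read by MTT assay, with a stated time of 72 h (on this read-out higher numbers stand for weaker inhibition and lower numbers for stronger inhibition), compound 3 `Cc1cc(Nc2cc(-c3ccccc3)[nH]n2)n2nc(SCc3ccc(C(F)(F)F)cc3)nc2n1` gives 42700 nM, the only actual number so far. Compound 1 `Cc1cc(Nc2cc(-c3ccccc3)[nH]n2)n2nc(SCC3CCCCC3)nc2n1` stands at > 50000 nM, which is a limit. Compound 2 `Cc1cc(Nc2cc(-c3ccccc3)[nH]n2)n2nc(SCc3cccc(Br)c3)nc2n1` stands at > 50000 nM, also a limit. Compound 4 `Cc1cc(Nc2cc(-c3ccccc3)[nH]n2)n2nc(SCc3cccc4ccccc34)nc2n1` differs from compound 3 as follows: naphthalen-1-yl in place of 4-(trifluoromethyl)phenyl on a saturated chain carbon bound to a sulfur. The measured steps that bear on this change are an at least 1.1-fold lower number from compound 1 to compound 3 (0.06 log units; that floor lies within the scatter) and an at least 1.1-fold lower number from compound 2 to compound 3 (0.06 log units; that floor lies within the scatter), and their floors lie within the scatter. Neither shows a change of this side-chain group moving the value beyond the scatter, so no step beyond the scatter is expected in this assay. The expected change is a 1.1-fold lower number from compound 3 to compound 4 (0.03 log units; within the scatter). For compound 4 the estimated value is 40000 nM, with an expected range of 18000 nM to 90000 nM.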

Compound 4, half-maximal inhibitory concentration: 36300 nM
Estimate against measurement, compound 4: 1.1-fold (0.04 log units) above; low and high end bracket the measured number.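

In this assay, among these compounds, naphthalen-1-yl on a saturated chain carbon bound to a sulfur gives a 1.2-fold lower number from compound 3 to compound 4 (0.07 log units; within the scatter), the first step at this position between two actual numbers. Replacing 4-(trifluoromethyl)phenyl with two aromatic carbon rings at the same heavy-atom count therefore does not move the value beyond the scatter. Against the other two side chains, only floors can be read, an at least 1.3-fold lower number from compound 2 to compound 4 (0.13 log units; that floor lies within the scatter) and an at least 1.3-fold lower number from compound 1 to compound 4 (0.13 log units; that floor lies within the scatter): the limit of > 50000 nM in this assay, at which 2 of the 4 values shown sit.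

Still open, going by these compounds, is whether an amine or a carboxylic acid on this side chain would move the value beyond the scatter.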